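Thiophen-3-yl for thiophen-2-yl across two cores

The source may report more compounds than this note shows. Statements on the series, on what has been measured and on what is new or still open speak of the compounds shown alone.

Measured so far:
compound 1, `CC1=C(C(=O)OCC(C)C)C(c2cccs2)NC(=O)N1C`: 5%
compound 2, `CC1=C(C(=O)OCC(C)C)C(c2ccsc2)NC(=O)N1C`: 4%
compound 3, `CCC(CC)OC(=O)C1=C(C)NC(=O)NC1c1cccs1`: 1%

In an assay on membranes from HeLa cells for displacement of a labelled ligand from adenosine receptor A3 (Homo sapiens), read by scintillation counting, with a stated time of 180 min, tested at 1 uM (a lower number here means less inhibition, a higher number more inhibition at the concentration tested (going by the name of the read-out)), compound 1 gives 5%, compound 2 gives 4% and compound 3 gives 1%; all three lie within the scatter of one another. Compound 1 and compound 2 differ by thiophen-3-yl in place of thiophen-2-yl on a saturated ring carbon, and the step is a number 1 percentage points lower from compound 1 to compound 2 (within the scatter). The difference between the core of compound 1 and the core of compound 3 is not broken down here.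

Compound 4, `CCC(CC)OC(=O)C1=C(C)NC(=O)NC1c1ccsc1`, is not yet measured in this assay. It differs from compound 3 by thiophen-3-yl in place of thiophen-2-yl on a saturated ring carbon, the same kind of change as in the first pair, though here the ring atom bears a group of 8 heavy atoms rather than an isobutoxycarbonyl group (7 heavy atoms). The expected step is a number 1 percentage points higher from compound 3 to compound 4 (within the scatter), since compound 3 sits at 1% and the earlier step of a number 1 percentage points lower from compound 1 to compound 2 (within the scatter) lay within the scatter. For compound 4 the estimate is 2%, between -5% and 9%.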

Compound 4, a percentage reported as inhibition, at one concentration (the size of the read-out at that concentration, not a potency): 6%
Compound 4: middle estimate off by 4 percentage points, on the low side, and the stated range covers the measured number.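

In this assay, thiophen-3-yl in place of thiophen-2-yl on a saturated ring carbon gives a number 5 percentage points higher from compound 3 to compound 4 (within the scatter), and the two cores can be compared directly: the same change on two cores in this assay, a number 1 percentage points lower (within the scatter) from compound 1 to compound 2 and a number 5 percentage points higher (within the scatter) from compound 3 to compound 4, 6 percentage points apart, within the scatter of two such steps. The swap therefore shows no detectable dependence on the core for these two pairs, and neither step can be told from scatter. This does not show that the two thiophene isomers are interchangeable in general: all four readings come from a single concentration, lie close together and give no potency.

Still open, on these data alone, is whether an amine or a carboxylic acid on the thiophene would move the reading clear of the scatter. A longer chain in place of the isobutoxycarbonyl group also remains untested among the compounds shown.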